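This account rests on a few compounds, and the source may have more. Where it says the series, first, only, none or still open, it means among the compounds named here.

Compound 1, `OB1OCc2ccc(-n3cccc3)cc21`. In an ADME assay on L929 cells (Mus musculus) for cytotoxicity, read by resazurin assay, with a stated time of 72 h (a lower number here means a stronger inhibitor, a higher number a weaker inhibitor), compound 1 gives > 10 ug/mL, which is a limit of the assay and not a number.
Compound 2, `O=C(c1ccccc1)c1ccn(-c2ccc3c(c2)B(O)OC3)c1`. In this assay compound 2 gives > 10 ug/mL, again a limit of the assay.
Compound 3, `O=C(CCc1ccccc1)c1ccn(-c2ccc3c(c2)B(O)OC3)c1`. In this assay compound 3 gives > 10 ug/mL, likewise a limit of the assay.

Compound 3 therefore stands at the ceiling of what was measured: the limit of > 10 ug/mL in this assay, at which 3 of the 3 values shown sit. Within the data shown here, the one step that can be drawn between measured compounds, a step that the two limits leave unreadable from compound 2 to compound 3, is not readable in size or direction, because both ends are limits. Among the measured compounds shown here, nothing among the measured compounds shows a step beyond the usual scatter.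

Compound 4, `CCCC(=O)c1ccn(-c2ccc3c(c2)B(O)OC3)c1`, differs from compound 3 by methyl in place of phenyl on a saturated chain carbon, two bonds along the chain from a carbonyl carbon. For the measured compounds named here, no measured step bears directly on this change, and the only related step, from a phenyl to a phenethyl on the carbonyl carbon, gave no readable number. The expectation for compound 4 is therefore that no step beyond the scatter appears in this assay, and that the step that the limit leaves unreadable from compound 3 to compound 4 is essentially flat, with compound 4 most likely reported again as a limit. Compound 4 is estimated at 20 ug/mL, with a range from 10 ug/mL to 60 ug/mL.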

Compound 4, half-maximal inhibitory concentration: > 10 ug/mL
Compound 4 was reported as a limit; the forecaster's own chance of this, stated with the estimate: 85%; the middle value does not contradict the limit.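

In this assay compound 4 gives > 10 ug/mL, again a limit of the assay and not a number. The steps to compound 4 from compound 1, compound 2 and compound 3 therefore cannot be read, and all four compounds stand at the same ceiling: the limit of > 10 ug/mL in this assay, at which 4 of the 4 values shown sit. The compounds shown leave open how far each lies from that limit, and whether any of these changes moves the read-out at all.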